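The source may hold more compounds than are shown below. What is called first, only, known or untested is meant among the compounds shown, and "the series" means these compounds.

Series notes, measured in a functional assay on MCF7 cells (Homo sapiens) for antiproliferative activity, read by MTT assay; a lower number here means a stronger inhibitor, a higher number a weaker inhibitor:

- compound 1 `COc1cc2c(Oc3ccc(NC(=O)Nc4cccc(C)c4)cc3)ccnc2cc1OCCCCCCC(=O)NO`: 1240 nM
- compound 2 `COc1cc2c(Oc3ccc(NC(=O)Nc4ccccc4F)cc3)ccnc2cc1OCCCCCCC(=O)NO`: 660 nM
- compound 3 `COc1cc2c(Oc3ccc(NC(=O)N/N=C/c4ccccc4F)cc3)ccnc2cc1OCCCCCCC(=O)NO`: 1610 nM

Compound 2 stands at 660 nM. It cannot be separated from compound 1, since a 1.9-fold lower number from compound 1 to compound 2 (0.27 log units; within the scatter) stays inside the noise of this assay. Its gap to compound 3 is clearer: a 2.4-fold higher number from compound 2 to compound 3 (0.39 log units; beyond the scatter).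

The next compound to consider is compound 4 `COc1cc2c(Oc3ccc(NC(=O)N/N=C/c4ccc(F)cc4)cc3)ccnc2cc1OCCCCCCC(=O)NO`, which keeps the shared core and the hydroxamic acid chain end of compound 2. The change is a group of 9 heavy atoms (7 carbon, 1 nitrogen, 1 fluorine; one six-membered aromatic ring of carbon only) in place of a group of 7 heavy atoms (6 carbon, 1 fluorine; one six-membered aromatic ring of carbon only), on an amide-type nitrogen. For the measured compounds named here, the group that enters has the same counts as the one carried by compound 3 at this amide-type nitrogen, and the two differ only in where the fluorine sits on the ring.

Going by the values given here, the closest precedent is therefore compound 3, through a 2.4-fold higher number from compound 2 to compound 3 (0.39 log units; beyond the scatter). A second step, a 1.3-fold higher number from compound 1 to compound 3 (0.11 log units; within the scatter), shows compound 3 not separated from compound 1. Among the compounds with values here, nothing measured so far shows what moving the fluorine does, so the precedent rests on one pair. A modest move to a higher number is expected, of about the size seen for compound 3, and the expected step is a 2.1-fold higher number from compound 2 to compound 4 (0.33 log units; beyond the scatter). The estimate for compound 4 is 1400 nM, with an expected range of 600 nM to 3200 nM.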

Compound 4, half-maximal inhibitory concentration: 1360 nM
Compound 4: middle estimate off by 1.0-fold (0.01 log units), on the high side, and the stated range covers the measured number.
By their numbers in this assay, from the lowest: compounds 2, 1, 4 and 3 (each within the scatter of the next, the first and the last beyond it).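

In this assay, a second compound now carries the group of 9 heavy atoms on the amide-type nitrogen: a 2.1-fold higher number from compound 2 to compound 4 (0.31 log units; beyond the scatter) matches the direction of the step to compound 3, so the move to a higher number against compound 2 no longer rests on one pair. The fluorine position, untested until now, does not separate the two compounds, as 4-fluorophenyl in place of 2-fluorophenyl on the carbon with a double bond to nitrogen gives a 1.2-fold lower number from compound 3 to compound 4 (0.07 log units; within the scatter). The same group is not separated from the 3-methylphenyl of compound 1, with a 1.1-fold higher number from compound 1 to compound 4 (0.04 log units; within the scatter), so compound 1 goes against any general reading of this group as weakening; no supporting data bear on why these numbers fall as they do.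

Open, going by these compounds, is how a phenyl without fluorine, a 3-fluorophenyl or a 4-methoxyphenyl on the carbon with a double bond to nitrogen would read against compound 3 and compound 4. Also open, on these data alone, is whether these small gaps would hold with a shorter chain or a carboxylic acid in place of the hydroxamic acid chain end.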